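A few compounds are considered here, and "the series" means these few. Any claim that something is new, unique, unknown or untested is made for them only; others in the source may bear on it.

Compound 1 `CC(C)COc1ccc(-c2cn3c(=O)n(-c4ccccc4)nc3c(N)n2)cc1` carries an isobutoxy-substituted aryl group on a shared core that also bears an amine. In an assay on cells for displacement of a labelled ligand from adenosine receptor A3 (Homo sapiens), read by scintillation counting, with a stated time of 3 h (a higher number here means a weaker inhibitor, a lower number a stronger inhibitor), compound 1 gives "not determined" (no result reported), so no number stands for it at all. A close relative, compound 2 `COc1ccc(-c2cn3c(=O)n(-c4ccccc4)nc3c(=O)[nH]2)cc1`, differs in having a methoxy group and a carbonyl on the core in place of the amine. In this assay compound 2 gives > 30000 nM, which is a limit of the measurement and not a number. Compound 1 therefore stands on nothing firm: of the two values shown, one is missing and the other sits at the limit of > 30000 nM in this assay, at which 1 of the 2 values shown sits. Compound 3 `CC(C)Oc1ccc(-c2cn3c(=O)n(-c4ccccc4)nc3c(N)n2)cc1` is the compound whose measurement follows. Its change from compound 1 is isopropyl in place of isobutyl on an oxygen on an aromatic ring. Among the compounds with values here, since no measured pair shows what such a change does here, the step from compound 1 to compound 3 in this assay is expected to be small, in no particular direction, and likely within the usual scatter. With so little to go on, compound 3 is estimated at 5000 nM, with a wide range from 300 nM to 30000 nM.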

Compound 3, inhibition constant: > 30000 nM
Compound 3: a limit, no number; the forecaster's own chance of this, stated with the estimate: 40%; at least 6.0-fold (0.77 log units) between middle value and limit.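

Within the data shown here, no number stands for compound 1 in this assay, so no step from it to compound 3 can be read. Compound 3 gives > 30000 nM, which is a limit and not a number. The values shown offer little else to compare: the limit of > 30000 nM in this assay, at which 2 of the 3 values shown sit.

The compounds shown leave open what isopropoxy in place of isobutoxy does to binding, in size or direction.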